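The compounds below may be only part of what the source reports. "The series", "measured", "known", "first", "only" and "open" are said of these compounds alone.

Compound 1 `Oc1ccccc1/C=N/c1nnc[nH]1`: > 30000 nM (a limit)
Compound 2 `COc1cccc(/C=N/c2nnc[nH]2)c1O`: > 30000 nM (a limit)

In a functional assay on PC-3 cells (Homo sapiens) for cytotoxicity (on this read-out lower numbers stand for stronger inhibition and higher numbers for weaker inhibition), compound 1 gives > 30000 nM, which is a limit and not a number. Compound 2, which carries methoxy in place of hydrogen on an aromatic carbon, gives > 30000 nM, also a limit. Going by the values given here, the only measured step is therefore a step that the two limits leave unreadable from compound 1 to compound 2, and the data so far amount to the limit of > 30000 nM in this assay, at which 2 of the 2 values shown sit. Compound 3 `CCOc1ccc(/C=N/c2nnc[nH]2)c(O)c1` brings a different change to the core of compound 1: ethoxy in place of hydrogen on an aromatic carbon. In words, this is ethoxy in place of hydrogen on an aromatic carbon. With no readable step to draw on, no shift in either direction is expected in this assay, and a further limit is the likeliest report. The expected change is a step that the limit leaves unreadable from compound 1 to compound 3. For compound 3 the estimate is 35000 nM, with an expected range from 15000 nM to 80000 nM.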

Compound 3, half-maximal inhibitory concentration: > 30000 nM
Compound 3 gave a limit, no number (the forecaster's own chance of this, stated with the estimate: 85%); the middle value does not contradict the limit.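

The result for compound 3 in this assay is again a limit and not a number, so no new step can be read from compound 1 to compound 3. The compounds shown leave open whether any change on the shared core reaches a readable value in this assay at all.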